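Fluoro in place of hydrogen on an inactive compound

The compounds below may be only part of what the source reports. "The series", "measured", "known", "first", "only" and "open" are said of these compounds alone.

In a functional assay on HT-29 cells (Homo sapiens) for inhibition (a lower number here means a stronger inhibitor, a higher number a weaker inhibitor), compound 1 `COCCOc1cc(/C=C/c2ccc3ccccc3c2)ccc1OC` gives only a limit, > 5000 nM. Compound 2 `COc1ccc(/C=C/c2ccc3ccccc3c2)cc1` also gives only a limit, > 5000 nM. All readings so far stand at the limit of > 5000 nM in this assay, at which 2 of the 2 values shown sit. Compound 3 `COc1ccc(/C=C/c2ccc3ccccc3c2)cc1F` differs from compound 2 by fluoro in place of hydrogen on an aromatic carbon, fluoro in place of hydrogen. For the measured compounds named here, the one measured step, a step that the two limits leave unreadable from compound 1 to compound 2, offers no size to carry over, so no step beyond the scatter is expected in this assay. The expected step is a step that the limit leaves unreadable from compound 2 to compound 3. Compound 3 is expected at 7000 nM, with an estimated range of 2500 nM to 20000 nM, and a further limit is the likeliest report.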

Compound 3, half-maximal inhibitory concentration: > 5000 nM
Compound 3: no number, only a limit (the forecaster's own chance of this, stated with the estimate: 75%); the middle value lies beyond the limit too.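

No step can be read among compound 1, compound 2 and compound 3 in this assay, since each reading is a limit and not a number: the limit of > 5000 nM in this assay, at which 3 of the 3 values shown sit. The compounds shown leave open how strongly, if at all, any of the three inhibits.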